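A Methoxy Added to Compound 1

This account rests on a few compounds, and the source may have more. Where it says the series, first, only, none or still open, it means among the compounds named here.

Among the measured compounds shown here, in an ADME assay on KB cells (Homo sapiens) for cytotoxicity, read by MTT assay, with a stated time of 72 h (on this read-out lower numbers stand for higher toxicity in this test and higher numbers for lower toxicity in this test), only two compounds have been measured so far. Compound 1 (`Clc1ccc(Nc2nc(-c3ccccn3)cs2)nc1`) gives 98600 nM, the higher of the two numbers and therefore the less toxic result. Compound 2 (`COc1ccc(Nc2nc(-c3ccccn3)cs2)nc1`) gives 13200 nM.

Compound 3 (`COc1ccnc(-c2csc(Nc3ccc(Cl)cn3)n2)c1`) has not yet been measured. Its difference from compound 1 is methoxy in place of hydrogen on an aromatic carbon of a six-membered aromatic ring with 1 nitrogen, meta to a large group and opposite the ring nitrogen. For the measured compounds named here, the one measured step that bears on this change is a 7.5-fold lower number from compound 1 to compound 2 (0.87 log units; beyond the scatter), which is modest but beyond the scatter. That step also brings in a methoxy, but there it replaces chloro at another place, while compound 3 keeps its chloro, so it is only a loose guide. A smaller move toward a lower number is therefore expected, a 2.2-fold lower number from compound 1 to compound 3 (0.34 log units; beyond the scatter). For compound 3, the estimated value is 45000 nM, with an expected range of 14000 nM to 120000 nM.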

Compound 3, half-maximal cytotoxic concentration: 62800 nM
Beside the measured number, compound 3's estimate is 1.4-fold (0.14 log units) below it; low and high end bracket the measured number.
By their numbers in this assay, from the lowest: compound 2; then compounds 3 and 1 (each within the scatter of the next).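

Placing methoxy on an aromatic carbon of a six-membered aromatic ring with 1 nitrogen, opposite the ring nitrogen, gives a 1.6-fold lower number from compound 1 to compound 3 (0.20 log units; within the scatter) in this assay, so at this position the change cannot be told apart from the ordinary spread of repeated measurements. The earlier step, a 7.5-fold lower number from compound 1 to compound 2 (0.87 log units; beyond the scatter), is beyond that spread, but there methoxy replaces chloro at another place on the molecule, so among these compounds the entry of a methoxy group does not give the same reading at both places. No measurement shown here offers a reason for either reading.

From the compounds shown here alone, whether this position tolerates change more generally remains open, since a single small group says little about how an amine, a carboxylic acid or a longer chain such as butoxy would read at the same carbon. It is also unknown whether methoxy at this position would read the same on compound 2, where methoxy has already taken the place of chloro.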